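Sulfonyl aryl swap and metabolic stability of quinoline analogues

A few compounds are considered here, and "the series" means these few. Any claim that something is new, unique, unknown or untested is made for them only; others in the source may bear on it.

Measured compounds:
compound 1, `O=S(=O)(c1cc(F)cc(F)c1)c1cnc2c(F)cccc2c1-c1cccc(Cl)c1`, 0.64 mL/min
compound 2, `O=S(=O)(c1ccc(F)c(Cl)c1)c1cnc2c(F)cccc2c1-c1ccc(Cl)cc1`, 0.01 mL/min

In an ADME assay on microsomes from liver (Homo sapiens) for metabolic stability, tested at 2.5 uM (on this read-out lower numbers stand for slow clearance and higher numbers for fast clearance), compound 2 gives 0.01 mL/min, the lowest of the two numbers, and compound 1 gives 0.64 mL/min. Compound 3, `O=S(=O)(c1cc(F)cc(F)c1)c1cnc2c(F)cccc2c1-c1ccc(Cl)cc1`, is not yet measured. Among the compounds with values here, it differs from compound 2 by 3,5-difluorophenyl in place of 3-chloro-4-fluorophenyl on a sulfonyl sulfur, and its sulfonyl arene is the one carried by compound 1. From the gap between compound 1 and compound 2, the step of a 12-fold higher number from compound 2 to compound 3 (1.08 log units; beyond the scatter) is expected to be upward and beyond the scatter. Compound 3 is estimated at 0.12 mL/min, within a range from 0.02 mL/min to 0.6 mL/min.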

Compound 3, intrinsic clearance in a liver preparation (reported as CLH), per the amount of preparation that the assay uses: 0.73 mL/min
The estimate for compound 3 lay 6.1-fold (0.78 log units) below the measured number; measured number above the stated range.
By their numbers in this assay, from the lowest: compound 2; then compounds 1 and 3 (each within the scatter of the next).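

Replacing 3-chloro-4-fluorophenyl with 3,5-difluorophenyl on a sulfonyl sulfur gives a 73-fold higher number from compound 2 to compound 3 (1.86 log units; beyond the scatter) in this assay and shows that this single change alone carries a large step. With 3,5-difluorophenyl in place, 4-chlorophenyl in place of 3-chlorophenyl on an aromatic carbon gives a 1.1-fold higher number from compound 1 to compound 3 (0.06 log units; within the scatter) and does not separate the two compounds. Nothing measured here explains the size of the sulfonyl step.

From the compounds shown here alone, it remains open whether the same sulfonyl change gives a similar step with 3-chlorophenyl on the core, and how in this assay a sulfonyl arene bearing an amine or a carboxylic acid would compare.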